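The source may hold more compounds than are shown below. What is called first, only, known or untested is meant among the compounds shown, and "the series" means these compounds.

Working notes on the series. Compound 1 `CCc1cc(-c2noc(-c3cc(C)cc(CN(C)CC)c3)n2)cc(C)c1OC[C@@H](O)CNC(=O)CO` is the reference. In an ADME assay on liver (strain Wistar) for metabolic stability, with Liver microsome (Rattus norvegicus) as the target, read by LC-MS, using microsomes and NADPH, with a stated time of 15 min, tested at 1 uM (a lower number here means slower removal, a higher number faster removal of the compound), compound 1 gives > 1250 mL.min-1.g-1, which is a limit of the assay rather than a number (the limit of > 1250 mL.min-1.g-1 in this assay, at which 1 of the 3 values shown sits). Compound 2 `CCCCN(C)Cc1cc(C)cc(-c2nc(-c3cc(C)c(OC[C@@H](O)CNC(=O)CO)c(CC)c3)no2)c1` gives 183 mL.min-1.g-1 and compound 3 `CCc1cc(-c2noc(-c3cc(C)cc(CN(C)CC(C)C)c3)n2)cc(C)c1OC[C@@H](O)CNC(=O)CO` gives 20 mL.min-1.g-1; the steps of an at least 6.8-fold lower number from compound 1 to compound 2 (0.83 log units; beyond the scatter) and an at least 62-fold lower number from compound 1 to compound 3 (1.79 log units; beyond the scatter) both change only the amine substituents. Compound 4 `CCc1cc(-c2noc(-c3cc(C)c(CN(C)C)s3)n2)cc(C)c1OC[C@@H](O)CNC(=O)CO` differs from compound 1 by 5-((dimethylamino)methyl)-4-methylthiophen-2-yl in place of 3-((ethyl(methyl)amino)methyl)-5-methylphenyl on an aromatic carbon. Within the data shown here, no measured step alters the aromatic ring itself, so the measured steps show only that compound 1 sits at the limit and that changes of the amine substituents have moved the number off it. For compound 4 a lower number than compound 1 is expected, with weak support, as an at least 1.7-fold lower number from compound 1 to compound 4 (0.25 log units; that floor lies within the scatter). The estimate for compound 4 is 700 mL.min-1.g-1, between 200 mL.min-1.g-1 and 1250 mL.min-1.g-1.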

Compound 4, intrinsic clearance in microsomes: 1220 mL.min-1.g-1
Beside the measured number, compound 4's estimate is 1.7-fold (0.24 log units) below it; low and high end bracket the measured number.
By their numbers in this assay, from the lowest: compound 3; then compound 2; then compound 4. At a limit, above all of these: compound 1.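

In this assay, replacing the aromatic ring gives an at least 1.0-fold lower number from compound 1 to compound 4 (0.01 log units; that floor lies within the scatter), so the change of 3-((ethyl(methyl)amino)methyl)-5-methylphenyl to 5-((dimethylamino)methyl)-4-methylthiophen-2-yl at this position shows no lowering that can be claimed. The true size of this step stays unknown because compound 1 does not give a number: the limit of > 1250 mL.min-1.g-1 in this assay, at which 1 of the 4 values shown sits.

This replacement changes the ring and the amine together, so their contributions remain unseparated. Also open, as far as these compounds go, is how this assay would read for the same thiophen-2-yl group carrying a morpholine in place of the dimethylamino group.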